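The source may hold more compounds than are shown below. What is called first, only, known or untested is meant among the compounds shown, and "the series" means these compounds.

In a functional assay (spleen, spleen) for activation, with Mus musculus as the target (a lower number here means that less compound is needed, a higher number that more compound is needed for the effect), compound 1 `Nc1ncnc2c1nc(O)n2Cc1ccc(Cl)cc1` gives 10 uM. Compound 2 `CCCCCNc1nc(N)c2nc(O)n(Cc3ccccc3)c2n1` gives 0.1 uM in this assay and stands lowest of the two numbers measured, the nearest being compound 1, whose gap to it lies well beyond the scatter. Compound 3 `CCCOc1nc(N)c2nc(O)n(Cc3ccccc3)c2n1` is not yet measured in this assay; against compound 2 it differs in one place: propoxy in place of pentylamino on an aromatic carbon. Within the data shown here, no step between measured compounds isolates this change, so its size is open. A modest rise in the number is expected, and compound 3 is estimated at 0.3 uM with a range of 0.1 uM to 3 uM. The expected step of a 3.0-fold higher number from compound 2 to compound 3 (0.48 log units; beyond the scatter) would sit just beyond the scatter.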

Compound 3, minimum effective concentration: 0.01 uM
Beside the measured number, compound 3's estimate is 30-fold (1.48 log units) above it, and the stated range ends above it.
By their numbers in this assay, from the lowest: compound 3; then compound 2; then compound 1.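

At the aromatic carbon between two ring nitrogen atoms, the group can change from pentylamino to propoxy with activity retained and improved: in this assay, the swap gives a 10-fold lower number from compound 2 to compound 3 (1.00 log units; beyond the scatter). The pentylamino hydrogen-bond donor is therefore not required at this position for a low number in this series. Nothing shown here bears on the reason for this step.

From the compounds shown here alone, the change alters the linking atom and the chain together, so their separate contributions remain open. Pentyloxy and propylamino at this position would separate them.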